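A few compounds are considered here, and "the series" means these few. Any claim that something is new, unique, unknown or untested is made for them only; others in the source may bear on it.

Series notes on metabolic stability. In an ADME assay on microsomes from liver (Homo sapiens) for metabolic stability, with a stated time of 30 min, tested at 1 uM (on this read-out lower numbers stand for a less stable compound and higher numbers for a more stable compound), compound 1 `CCC1C(=O)N(C)c2cnc(-n3ccnc3-c3ccccc3)nc2N1c1ccccc1` gives 21%, compound 2 `CC[C@@H]1C(=O)N(C)c2cnc(-n3ccnc3-c3ccccc3)nc2N1[C@@H]1CCOC1` gives 10%, and compound 3 `CC[C@@H]1C(=O)N(C)c2cnc(-c3cn[nH]c3-c3ccc(F)cc3F)nc2N1c1cnn(C)c1` gives 48%. Compound 2 stands lowest of the three numbers: its nearest neighbour is compound 1, whose number is higher by a gap beyond the scatter, and its furthest is compound 3, higher by a gap that is also beyond the scatter. No two of these three compounds differ in only one place, so no single-change step can be read off the measured set, and the compound 1 to compound 2 gap mixes two changes at once.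

Compound 4 `CC[C@@H]1C(=O)N(C)c2cnc(-n3ccnc3-c3ccccc3)nc2N1CCC(F)(F)F` is the next member to be run in this assay. Against compound 2 the difference is 3,3,3-trifluoropropyl in place of oxolan-3-yl on a nitrogen on an aromatic ring in a ring. The change takes out the one ring and the one hydrogen-bond acceptor of the oxolan-3-yl group and brings in three fluorine atoms on a three-carbon chain.

Within the data shown here, with no measured step available for a change of this kind, the expectation rests on compound 2 alone. A step of a number 10 percentage points higher from compound 2 to compound 4 (within the scatter) is expected, an increase that sits near the edge of the scatter rather than clearly beyond it. For compound 4 the estimated value in this assay is 20%, with a range from 6% to 45%.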

Compound 4, percent of the compound remaining in the Homo sapiens assay: 0%
The estimate for compound 4 lay 20 percentage points above the measured number; measured number outside the range, below it.
By their numbers in the Homo sapiens assay, from the lowest: compounds 4 and 2 (each within the scatter of the next); then compound 1; then compound 3.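

Among these compounds, in the Homo sapiens assay, the first single-change step reads a number 10 percentage points lower from compound 2 to compound 4 (within the scatter), so on this nitrogen the open 3,3,3-trifluoropropyl chain and the oxolan-3-yl ring cannot be told apart by the percent of compound remaining. In a physicochemical assay for lipophilicity (on this read-out lower numbers stand for lower lipophilicity and higher numbers for higher lipophilicity), compound 2 gives 1.8 and compound 4 gives 3.1. The same replacement thus shifts lipophilicity by a large margin while the stability step stays within the scatter, so at this position a rise in lipophilicity of this size comes with no stability difference that can be resolved: the measured partition coefficient of compound 2, 1.8, and of compound 4, 3.1, a number 1.30 log units higher (beyond the scatter)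

Going by these compounds, compound 1 and compound 3 each differ from compound 2 and compound 4 in more than one place, so it stays open whether the low stability of this pair belongs to the group on this nitrogen or to other parts of the structure. Also open, on these data alone, is what a plain propyl chain or a morpholine-bearing chain would give on this nitrogen, which would separate the loss of the ring from the arrival of the three fluorine atoms.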